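A Smaller Basic Arm in Place of the Ester Chain

The source may report more compounds than this note shows. Statements on the series, on what has been measured and on what is new or still open speak of the compounds shown alone.

Compound 1 `CCOC(=O)C(C)Nc1cccc2c(S(=O)(=O)Nc3onc(C)c3C)cccc12` was tested in an assay on VSM-A10 cells for antagonist activity at Endothelin-1 receptor (Rattus norvegicus) (on this read-out higher numbers stand for weaker inhibition and lower numbers for stronger inhibition), where compound 1 gives 400 nM. That is the lowest of the three numbers available. Compound 2 `Cc1noc(NS(=O)(=O)c2cccc([N+](=O)[O-])c2)c1C` gives 7800 nM in this assay, a number that lies beyond the scatter above compound 1. Compound 3 `Cc1noc(NS(=O)(=O)c2cccc3c(N(C)C)cccc23)c1-c1ccccc1` gives 15900 nM in this assay, further still from compound 1. Among the measured compounds shown here, neither compound 2 nor compound 3 differs from compound 1 in a single place, so no step between measured compounds can be followed, and the account rests on what the three values show.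

Compound 4 `Cc1noc(NS(=O)(=O)c2cccc3c(CN(C)C)cccc23)c1C` is the untested member of the set. It departs from compound 1 in one place: (dimethylamino)methyl in place of (1-(ethoxycarbonyl)ethyl)amino on an aromatic carbon. The rest of compound 1 stays as it is, and only the group on that aromatic carbon is exchanged.

The direction of the step is taken as upward, toward weaker inhibition, because compound 1 gives 400 nM while every other compound measured lies well above it. The step from compound 1 to compound 4 is expected to be a 3.8-fold higher number from compound 1 to compound 4 (0.57 log units; beyond the scatter), a change beyond the scatter. Compound 4 is estimated at 1500 nM, within a range from 300 nM to 8000 nM.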

Compound 4, half-maximal inhibitory concentration: 2800 nM
Compound 4: middle estimate off by 1.9-fold (0.27 log units), on the low side; low and high end bracket the measured number.
By their numbers in this assay, from the lowest: compound 1; then compound 4; then compound 2; then compound 3.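

Among the compounds shown here, the exchange gives the first step in this set that can be followed at a single place: in this assay, (dimethylamino)methyl in place of (1-(ethoxycarbonyl)ethyl)amino gives a 7.0-fold higher number from compound 1 to compound 4 (0.85 log units; beyond the scatter) with the rest of the structure unchanged. It shows that the group on this aromatic carbon, ortho to a fused ring and meta to a fused ring, bears on the read-out, and that the group with 8 heavy atoms gives the lower number of the two, while the one with 4 heavy atoms, which has no hydrogen-bond donor, still gives a measurable number. No measurement presented here links this step to any particular feature of either group.

The exchange alters the atom attached to the ring, the length of the group and the presence of the ester all at once, so the compounds shown cannot say which of these accounts for the step. A carboxylic acid in place of the ethyl ester, or a longer chain ending in a diethylamino group, would be needed on the same aromatic carbon to begin separating them.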